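A thiourea chain variant of compound 1

The compounds below may be only part of what the source reports. "The series", "measured", "known", "first", "only" and "open" are said of these compounds alone.

For the measured compounds named here, compound 1 `C/N=C(/NC#N)NCCCCCn1nc(-c2ccccc2)ccc1=O` is the one compound here with a plain number: in a functional assay on the whole organism (stomach) with Rattus norvegicus as the target (a lower number here means that less compound is needed, a higher number that more compound is needed for the effect), compound 1 gives 100 mg/kg. Compound 2 `CC/N=C(/NC#N)NCCCCCCn1nc(-c2ccccc2)ccc1=O` reaches only a limit of the assay, > 100 mg/kg. Compound 3 `C/N=C(/NC#N)NCCCCCn1nc(-c2ccccc2)cc(C)c1=O` likewise gives only a limit, > 100 mg/kg. The two measured steps, a number no lower from compound 1 to compound 2 (the limit leaves the size open) and a number no lower from compound 1 to compound 3 (the limit leaves the size open), point no lower but leave their size open, since the limit of > 100 mg/kg in this assay, at which 2 of the 3 values shown sit, marks where they sit. Compound 4 `C=CCNC(=S)NCCCCn1nc(-c2ccccc2)ccc1=O` differs from compound 1 by a group of 7 heavy atoms (4 carbon, 2 nitrogen, 1 sulfur; no ring) in place of a group of 8 heavy atoms (4 carbon, 4 nitrogen; no ring), on a saturated chain carbon, four bonds along the chain from an aromatic nitrogen. Neither measured step touches this kind of exchange, so the expectation rests on compound 1 alone and on the two limits. Compound 4 is expected at an estimated 120 mg/kg, ranging from 50 mg/kg to 300 mg/kg. This estimated step, a 1.2-fold higher number from compound 1 to compound 4 (0.08 log units; within the scatter), is expected to stay within the scatter.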

Compound 4, dose for half-maximal effect: > 100 mg/kg
Compound 4: no number, only a limit (the forecaster's own chance of this, stated with the estimate: 55%); the middle value is on the limit's open side.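

Compound 4 gives > 100 mg/kg in this assay, which is a limit of the assay and not a number. For the compounds shown here, the step is a number no lower from compound 1 to compound 4 (the limit leaves the size open); its size cannot be read, and it shows only that the group of 7 heavy atoms (4 carbon, 2 nitrogen, 1 sulfur; no ring) at this place brings no lower number, as with the two earlier changes. Most of the values now sit at the same limit: the limit of > 100 mg/kg in this assay, at which 3 of the 4 values shown sit.

On these data alone, whether another group here, such as an amine or a carboxylic acid, would give a lower number than compound 1 stays open. As far as these compounds go, how far compound 2, compound 3 and compound 4 lie past the limit is also open.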